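Cyclopropyl for propyl at the benzylamide in a cytotoxicity series

The source may report more compounds than this note shows. Statements on the series, on what has been measured and on what is new or still open speak of the compounds shown alone.

Compound 1 `CCc1cc(CNC(=O)c2cc3nc(C)c([C@H](OC(C)(C)C)C(=O)O)c(-c4cc(F)c5c(c4C)CCCO5)n3n2)ccc1F` and compound 2 `CCCc1cc(CNC(=O)c2cc3nc(C)c([C@H](OC(C)(C)C)C(=O)O)c(-c4cc(F)c5c(c4C)CCCO5)n3n2)ccc1F` share one core and differ in a single place. In an ADME assay on MT2 cells (Homo sapiens) for cytotoxicity (on this read-out higher numbers stand for lower toxicity in this test and lower numbers for higher toxicity in this test), compound 1 gives > 40000 nM, which is a limit of the assay and not a number. In this assay compound 2 gives > 20000 nM, again a limit of the assay rather than a number. The step that the two limits leave unreadable from compound 1 to compound 2 thus has no readable size; its two ends sit at the limit of > 20000 nM in this assay, at which 1 of the 2 values shown sits, and (the limit of > 40000 nM in this assay, at which 1 of the 2 values shown sits).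

Where compound 2 stands: at one of the two limits shown, with the only other value also a limit, so no order between compound 1 and compound 2 can be stated.

Compound 3 `Cc1nc2cc(C(=O)NCc3ccc(F)c(C4CC4)c3)nn2c(-c2cc(F)c3c(c2C)CCCO3)c1[C@H](OC(C)(C)C)C(=O)O` differs from compound 2 as follows: cyclopropyl in place of propyl on an aromatic carbon. Going by the values given here, the one measured step concerns the same place but its size is not readable, and no measured step covers the change from propyl to cyclopropyl. No step beyond the scatter in this assay is therefore expected; the expected step that the limit leaves unreadable from compound 2 to compound 3 is flat. Compound 3 is estimated at 40000 nM, within 15000 nM to 100000 nM, and most likely again reported only as a limit.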

Compound 3, half-maximal cytotoxic concentration: > 40000 nM
Compound 3 gave a limit, no number (the forecaster's own chance of this, stated with the estimate: 80%); the middle value lies on the limit itself.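

In this assay compound 3 gives > 40000 nM, a limit of the assay and not a number. No size can be read for the steps linking compound 3 with compound 1 and compound 2. The compounds shown leave open whether ethyl, propyl and cyclopropyl on this aromatic carbon differ at all in cytotoxicity.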